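Chain shortening at the ether on the core of compound 2

The compounds below may be only part of what the source reports. "The series", "measured", "known", "first", "only" and "open" are said of these compounds alone.

Within the data shown here, compound 2 `CCCCCCCCCCCO[C@@H]1[C@@H](O)[C@H](O[C@H]2O[C@H](CN)[C@@H](O)[C@H](O)[C@H]2N)[C@@H](N)C[C@H]1N` sits at the low end of the three numbers so far: in an ADME assay on J774 cells (Mus musculus) for cytotoxicity, read by MTT assay, with a stated time of 24 h, tested at 10 uM (a lower number here means a stronger effect, a higher number a weaker effect of the compound at the concentration tested), compound 2 gives 74.7%. Its nearest neighbour is compound 3 `CCCCCCCCCCCO[C@@H]1[C@@H](N)[C@@H](O[C@H]2[C@H](O)[C@@H](O)[C@H](N)C[C@@H]2N)O[C@H](CN)[C@H]1O`, which in this assay gives 81.8%, a gap within the scatter; furthest is compound 1 `CCCCCCCCCCCO[C@@H]1[C@@H](N)[C@@H](O[C@H]2[C@H](O)[C@@H](OCCCCCCC)[C@H](N)C[C@@H]2N)O[C@H](CN)[C@H]1O`, which in this assay gives 88.4%, a gap beyond the scatter. Compound 4 `CCCCCCCO[C@@H]1[C@@H](O)[C@H](O[C@H]2O[C@H](CN)[C@@H](O)[C@H](O)[C@H]2N)[C@@H](N)C[C@H]1N` differs from compound 2 in one place: hydrogen in place of butyl on a saturated chain carbon, seven bonds along the chain from an oxygen on a saturated carbon. Among the measured compounds shown here, the only measured step that bears on shortening such a chain is a number 6.6 percentage points lower from compound 1 to compound 3 (within the scatter), and it stayed within the scatter. No step beyond the scatter is therefore expected in this assay, in either direction. The expected step is a number 3.3 percentage points higher from compound 2 to compound 4 (within the scatter). For compound 4 the estimate in this assay is 78%, with a range from 65% to 92%.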

Compound 4, a percentage reported as activity, at one concentration (the size of the read-out at that concentration, not a potency): 84.3%
For compound 4 the middle estimate is 6.3 percentage points below the measured one; low and high end bracket the measured number.
By their numbers in this assay, from the lowest: compounds 2, 3, 4 and 1 (each within the scatter of the next, the first and the last beyond it).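

In this assay, the shortening at this ether gives a number 9.6 percentage points higher from compound 2 to compound 4 (within the scatter), so hydrogen in place of butyl, seven bonds along the chain from an oxygen on a saturated carbon, does not move the read-out past the scatter. The second new step, a number 4.1 percentage points lower from compound 1 to compound 4 (within the scatter), also stays within the scatter. Nothing at hand bears on a cause for either step. Still open, going by these compounds, is how a chain longer than undecyl, or a carboxylic acid in place of the chain, would read in this assay.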